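A few compounds are considered here, and "the series" means these few. Any claim that something is new, unique, unknown or untested is made for them only; others in the source may bear on it.

Measured so far:
compound 1, `Nc1nc(Cl)c2ncn(Cc3ccccc3CCl)c2n1`, 30900 nM in a functional assay on HOP-92 cells (Homo sapiens) for cytotoxicity, read by sulforhodamine B assay, with a stated time of 48 h; a lower number here means a stronger inhibitor of growth, a higher number a weaker inhibitor of growth
compound 2, `ClCc1ccccc1Cn1cnc2ncnc(Cl)c21`, 12900 nM

Compound 1 has the highest number of the two in this assay; the nearest is compound 2, whose number is lower by more than the usual scatter, so compound 1 is the weaker of the pair.

The step considered here goes from compound 1 to compound 3, `ClCc1ccccc1Cn1cnc2c(Cl)ncnc21`, which has not yet been measured in this assay. The change is hydrogen in place of amino on an aromatic carbon. Within the data shown here, no pair of measured compounds shows this kind of change directly, so the size of the step can only be guessed. Taking compound 2, which also lacks the amino group, as a rough guide, a modest fall in the number is expected, about the size of the usual scatter or a little beyond it, rather than a large shift. Compound 3 is therefore estimated to give 16000 nM, with a plausible range from 5000 nM to 50000 nM, an expected step of a 1.9-fold lower number from compound 1 to compound 3 (0.29 log units; within the scatter).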

Compound 3, concentration for total growth inhibition: 4260 nM
Compound 3: middle estimate off by 3.8-fold (0.57 log units), on the high side; the measured number lies below the stated range.
By their numbers in this assay, from the lowest: compound 3; then compound 2; then compound 1.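

Replacing amino with hydrogen on the aromatic carbon between two ring nitrogen atoms gives, in this assay, a 7.3-fold lower number from compound 1 to compound 3 (0.86 log units; beyond the scatter). Among these compounds, this is the first direct reading of this change at this position, and it is larger than the usual scatter, so the difference between these two compounds can be taken as real. The amino group is therefore not required for growth inhibition in these cells, and the compound with hydrogen in its place is the stronger of this pair. Nothing shown here bears on why the number falls.

The compounds shown leave open how a methyl group, a methoxy group or a larger amine on this same carbon would compare with hydrogen and amino. As far as these compounds go, it also remains open whether the step would keep its size if the chloro group on the same ring were replaced by an amine.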